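A few compounds are considered here, and "the series" means these few. Any claim that something is new, unique, unknown or untested is made for them only; others in the source may bear on it.

Measured so far in a functional assay on HeLa cells (Homo sapiens) for antiproliferative activity, read by MTT assay, with a stated time of 72 h; on this read-out higher numbers stand for weaker inhibition and lower numbers for stronger inhibition:
- compound 1 `CCCCCc1ccc(-c2cn(C[C@H](O)[C@H]3OC(=O)C(OCc4ccccc4)=C3OCc3ccccc3)nn2)cc1`: 8390 nM
- compound 2 `O=C1O[C@H]([C@@H](O)Cn2cc(CNS(=O)(=O)c3ccc(Cl)cc3)nn2)C(OCc2ccccc2)=C1OCc1ccccc1`: 13600 nM

Among the measured compounds shown here, compound 2, at 13600 nM, cannot be told apart from the only other measured compound: a 1.6-fold higher number from compound 1 to compound 2 (0.21 log units; within the scatter), a gap within the usual scatter.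

Compound 3 `O=C1O[C@H]([C@@H](O)Cn2ccnn2)C(OCc2ccccc2)=C1OCc1ccccc1` keeps the core of compound 2 and differs from it as follows: hydrogen in place of (((4-chlorophenyl)sulfonyl)amino)methyl on an aromatic carbon. In words, hydrogen stands in place of (((4-chlorophenyl)sulfonyl)amino)methyl on an aromatic carbon.

For the measured compounds named here, only one measured step bears on this change, and only in part. In it, one large group replaced another on that same carbon, and the numbers stayed within the scatter. Going by the values given here, no measured compound has a bare hydrogen there, so the data give no firm direction for removing the group altogether. The expectation in this assay is therefore no step beyond the scatter, with a wide margin on either side. The expected change is a 1.5-fold higher number from compound 2 to compound 3 (0.17 log units; within the scatter). Compound 3 is expected at 20000 nM, with an estimated range from 7000 nM to 60000 nM.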

Compound 3, half-maximal inhibitory concentration: > 100000 nM
Compound 3 ended at the assay's limit; the forecaster's own chance of this, stated with the estimate: 20%; at least 5.0-fold (0.69 log units) between middle value and limit.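

In this assay, this carbon of the five-membered aromatic ring with 3 nitrogen behaves differently when it carries no group at all. Exchanging one large group for another had left the numbers within the scatter, a 1.6-fold higher number from compound 1 to compound 2 (0.21 log units; within the scatter), whereas replacing either large group with hydrogen gives a clear loss of activity: an at least 7.3-fold higher number from compound 2 to compound 3 (0.86 log units; beyond the scatter), and an at least 11-fold higher number from compound 1 to compound 3 (1.07 log units; beyond the scatter). The reading for compound 3 is a limit of the assay and not a number, so these two steps give only a minimum size: the limit of > 100000 nM in this assay, at which 1 of the 3 values shown sits.

Compound 1 and compound 2 both carry a six-membered aromatic ring of carbon only within their large groups, although the groups otherwise differ, so the compounds shown do not tell whether that ring matters or whether any group on this carbon would be enough. From the compounds shown here alone, a methyl group, a hydroxymethyl group or a plain pentyl chain at this place would help to separate those two possibilities, and how much of the activity each one keeps remains open.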